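Carboxyphenyl in place of chlorophenyl on the weakest member

This account rests on a few compounds, and the source may have more. Where it says the series, first, only, none or still open, it means among the compounds named here.

Compound 3 `CCCCCCCCc1ccc(OCC(=O)Cn2nnnc2-c2ccccc2Cl)cc1` was tested in an assay on microsomes from brain for inhibition of Fatty-acid amide hydrolase 1 (Rattus norvegicus), read by fluorescence and HPLC, with a stated time of 60 min (a higher number here means a weaker inhibitor, a lower number a stronger inhibitor), where compound 3 gives 4600 nM. Among the three measured compounds this is the highest number: compound 1 `CCCCCCCCc1ccc(OCC(=O)Cn2nnc(-c3ccccn3)n2)cc1` gives 18 nM and compound 2 `CCCCCCCCc1ccc(OCC(=O)Cn2nnc(-c3ccc(C(=O)O)cc3)n2)cc1` gives 90 nM, so compound 3 stands well apart from both, with compound 1 the furthest away. Compound 4 `CCCCCCCCc1ccc(OCC(=O)Cn2nnnc2-c2ccc(C(=O)O)cc2)cc1` has not been measured. The change from compound 3 to compound 4 is 4-carboxyphenyl in place of 2-chlorophenyl on an aromatic carbon.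

Within the data shown here, only one measured step touches a 4-carboxyphenyl, the one between compound 1 and compound 2, a 5.0-fold higher number from compound 1 to compound 2 (0.70 log units; beyond the scatter), and there the group enters in place of pyridin-2-yl on a different core, not in place of 2-chlorophenyl. Among the measured compounds shown here, no measured pair shows the exchange of 2-chlorophenyl for any other aryl on the core of compound 3. For the measured compounds named here, the one available step therefore gives only a weak hint that a 4-carboxyphenyl does not make the number lower, and a step of modest size toward a higher number, or none beyond the scatter, is expected for compound 4.

Compound 4 is estimated at 7000 nM, with a range from 1500 nM to 30000 nM, which would mean an expected step of a 1.5-fold higher number from compound 3 to compound 4 (0.18 log units; within the scatter).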

Compound 4, half-maximal inhibitory concentration: 3400 nM
The estimate for compound 4 lay 2.1-fold (0.31 log units) above the measured number; low and high end bracket the measured number.
By their numbers in this assay, from the lowest: compound 1; then compound 2; then compounds 4 and 3 (each within the scatter of the next).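

In this assay, among these compounds, the exchange of 2-chlorophenyl for 4-carboxyphenyl on the aromatic carbon of the core gives a 1.4-fold lower number from compound 3 to compound 4 (0.13 log units; within the scatter) and is the first measured exchange of one aryl group for another at this position. On this core, a group that brings a hydrogen-bond donor and a hydrogen-bond acceptor where the 2-chlorophenyl has neither does not separate compound 4 from compound 3 beyond the scatter. The 4-carboxyphenyl does not by itself fix the level of the number: with this same group, compound 2 gives 90 nM and, on the other core, compound 4 gives 3400 nM, so both compounds on the core of compound 3 remain at high numbers whichever of the two aryl groups is present.

Still open, going by these compounds, is whether a pyridin-2-yl, an unsubstituted phenyl or a methyl ester in place of the carboxylic acid would also leave the number on this core within the scatter, and how a 2-chlorophenyl would behave on the core of compound 1. Nothing measured here explains why this exchange leaves the two numbers so close.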